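A few compounds are considered here, and "the series" means these few. Any claim that something is new, unique, unknown or untested is made for them only; others in the source may bear on it.

Measured so far in a functional assay on HCT-116 cells (Homo sapiens) for antiproliferative activity, read by MTT assay, with a stated time of 72 h; on this read-out lower numbers stand for stronger inhibition and higher numbers for weaker inhibition:
compound 1 `O=C(CCc1cccc2c1B(O)OC2)Nc1ccc(F)cc1` — 650 nM
compound 2 `O=C(CCc1cccc2c1B(O)OC2)Nc1ccc(Br)cc1` — 46000 nM
compound 3 `CC(C)(C)c1ccc(NC(=O)CCc2cccc3c2B(O)OC3)cc1` — 19000 nM

Compound 1 gives the lowest number of the three; its nearest neighbour is compound 3 and its furthest is compound 2, both steps beyond the scatter. Compound 4 `CCOC(=O)c1ccc(NC(=O)CCc2cccc3c2B(O)OC3)cc1` is yet to be measured. It differs from compound 1 in one place: ethoxycarbonyl in place of fluoro on an aromatic carbon. For the measured compounds named here, two measured steps bear on this change, since each also swaps the fluoro of compound 1 for a different substituent on the same ring: a 71-fold higher number from compound 1 to compound 2 (1.85 log units; beyond the scatter) and a 29-fold higher number from compound 1 to compound 3 (1.47 log units; beyond the scatter). Both are large rises. A large step upward in this assay is therefore expected for compound 4, of about a 23-fold higher number from compound 1 to compound 4 (1.36 log units; beyond the scatter). Compound 4 is estimated at 15000 nM, with a range from 4000 nM to 60000 nM.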

Compound 4, half-maximal inhibitory concentration: > 100000 nM
Compound 4: no number, only a limit; the forecaster's own chance of this, stated with the estimate: 10%; middle value at least 6.6-fold (0.82 log units) from the limit.
By their numbers in this assay, from the lowest: compound 1; then compound 3; then compound 2. At a limit, above all of these: compound 4.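

In this assay compound 4 gives > 100000 nM as a limit of the assay, not a number. Against fluoro the change gives an at least 150-fold higher number from compound 1 to compound 4 (2.18 log units; beyond the scatter) and against tert-butyl it gives an at least 5.2-fold higher number from compound 3 to compound 4 (0.72 log units; beyond the scatter) while against bromo it gives an at least 2.1-fold higher number from compound 2 to compound 4 (0.33 log units; beyond the scatter) (ethoxycarbonyl is thus the weakest of the four on this aromatic carbon). This position therefore tolerates even less than the bromo and tert-butyl compounds showed.

On these data alone, whether the ester function or the ethyl chain drives this stays open: a carboxylic acid, a methyl ester or a primary amide at this position would separate them. As far as these compounds go, how far compound 4 lies past its limit also stays open.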